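The compounds below may be only part of what the source reports. "The series", "measured", "known", "first", "only" and "open" are said of these compounds alone.

Measured so far:
- compound 1 `CN1C(=O)C(C2=NS(=O)(=O)c3cc(NS(C)(=O)=O)ccc3N2)=C(O)C2CCCC21` — "not determined" (no result reported)
- compound 2 `CC(C)(C)CCN1C(=O)C(C2=NS(=O)(=O)c3cc(NS(C)(=O)=O)ccc3N2)=C(O)C2CCCCCCC21` — "not determined" (no result reported)
- compound 3 `CS(=O)(=O)Nc1ccc2c(c1)S(=O)(=O)N=C(C1=C(O)[C@H]3CCC[C@H]3N(Cc3ccc(C(F)(F)F)cc3)C1=O)N2` — > 33000 nM

The read-out here is an ADME assay on Huh-7 cells (Homo sapiens) for cytotoxicity, with a stated time of 72 h; a higher number here means that more compound is tolerated, a lower number that less compound is tolerated. Compound 1 has no number of its own in this assay, since its result was never reported, and the same holds for compound 2. For compound 3 the result in this assay is a limit rather than a number, > 33000 nM. Within the data shown here, that leaves the limit of > 33000 nM in this assay, at which 1 of the 3 values shown sits, as the only guide to where this series sits: one of the three entries is at that limit, and none shows measurable toxicity.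

Compound 4 `CC(C)N1C(=O)C(C2=NS(=O)(=O)c3cc(NS(C)(=O)=O)ccc3N2)=C(O)C2CCCC21` is the next compound. It differs from compound 1 by isopropyl in place of methyl on an amide-type nitrogen in a ring. Among the measured compounds shown here, since no step between two measured compounds exists here, there is no measured change to build on. Given the single limit seen, the expectation for compound 4 is no step beyond the usual scatter in this assay, in either direction. Compound 4 is therefore estimated at 40000 nM, with a range from 10000 nM to 150000 nM.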

Compound 4, half-maximal cytotoxic concentration: > 33000 nM
Compound 4: only a limit was reported (the forecaster's own chance of this, stated with the estimate: 75%); the middle value lies beyond the limit too.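

No step can be read between compound 1 and compound 4: compound 1 has no number in this assay. Compound 4 gives > 33000 nM, which is a limit and not a number. The compounds shown leave open whether the group on the amide-type nitrogen changes how much compound is tolerated.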